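This account rests on a few compounds, and the source may have more. Where it says the series, first, only, none or still open, it means among the compounds named here.

Measured so far:
- compound 1 `CCC[C@@H](OC(C)=O)C1=C(Br)C(=C(Br)Br)OC1=O`: 0.5 ug/mL
- compound 2 `CCCCC1=C(Br)/C(=C/Br)OC1=O`: > 20 ug/mL
- compound 3 `CCC[C@@H](OC(C)=O)C1=C(Br)[C@@](OC)(C(Br)Br)OC1=O`: 3.9 ug/mL

In a functional assay on KB cells (Homo sapiens) for cytotoxicity (a higher number here means that more compound is needed for the effect, a lower number that less compound is needed), compound 1 gives 0.5 ug/mL, the lowest of the two plain numbers, so it needs the least compound for the effect. Compound 3 gives 3.9 ug/mL in this assay, a higher number that lies beyond the usual scatter. For compound 2 the result is only a limit of the assay, > 20 ug/mL, and not a number (the limit of > 20 ug/mL in this assay, at which 1 of the 3 values shown sits). The unmeasured compound 4 `CCCCC1=C(Br)C(=C(Br)Br)OC1=O` differs from compound 1 by one change: hydrogen in place of acetoxy on a saturated chain carbon bound to a double-bonded ring carbon and a saturated chain carbon. Among the compounds with values here, no step between two measured compounds isolates this change, so its size is not known from the data. Compound 4 carries the same dibromomethylene as compound 1, which stands well, but lacks the acetoxy, which compound 2, also without acetoxy, lacks too while giving only a limit. A step toward a higher number, beyond the scatter, is expected from compound 1 to compound 4, a 16-fold higher number from compound 1 to compound 4 (1.20 log units; beyond the scatter), so compound 4 is estimated at 8 ug/mL, between 2 ug/mL and 30 ug/mL.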

Compound 4, concentration for half-maximal effect: > 20 ug/mL
Compound 4: only a limit was reported (the forecaster's own chance of this, stated with the estimate: 35%); at least 2.5-fold (0.39 log units) between middle value and limit.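

Within the data shown here, this is the first direct reading of what the acetoxy on this saturated chain carbon contributes: in this assay, hydrogen in place of acetoxy gives an at least 40-fold higher number from compound 1 to compound 4 (1.60 log units; beyond the scatter), although the dibromomethylene of compound 1 stays in compound 4. Compound 4 gives > 20 ug/mL, which is a limit of the assay and not a number. The dibromomethylene alone is therefore not enough to keep the low number of compound 1, and both compounds without acetoxy, compound 2 and compound 4, end at the same limit: the limit of > 20 ug/mL in this assay, at which 2 of the 4 values shown sit.

The compounds shown compare only acetoxy and hydrogen at this carbon, so it remains open whether a free hydroxyl or a longer ester, such as a butyrate, would keep the low number. They also leave open how far beyond the limit compound 4 really lies.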